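The source may report more compounds than this note shows. Statements on the series, on what has been measured and on what is new or still open speak of the compounds shown alone.

Measured so far in an assay on CHO cells for displacement of a labelled ligand from 5-hydroxytryptamine receptor 1B (Homo sapiens); on this read-out higher numbers stand for weaker inhibition and lower numbers for stronger inhibition:
compound 1 `CC(=O)Nc1ccc(CN2CCN(CCCc3c[nH]c4ccc(-n5cnnc5)cc34)CC2)cc1` gives 56 nM
compound 2 `CN(C)C(=O)C(c1ccccc1)N1CCN(CCCc2c[nH]c3ccc(-n4cnnc4)cc23)CC1` gives 102 nM
compound 3 `CN1CCN(CCCCc2c[nH]c3ccc(-n4cnnc4)cc23)CC1` gives 5100 nM

Compound 1 stands at the lowest of the three numbers in this assay. Compound 2 sits within the scatter of it, so the two cannot be told apart on this read-out, while compound 3 lies far beyond the scatter and is the weakest of the three. Compound 4 `c1ccc(CCCN2CCN(CCCc3c[nH]c4ccc(-n5cnnc5)cc34)CC2)cc1` has not yet been measured. It differs from compound 1 by phenethyl in place of 4-acetamidophenyl on a saturated chain carbon bound to an amine nitrogen in a ring. Among the compounds with values here, no measured pair shows this exact change, so its size has to be estimated from the spread of the three numbers. Compound 1 and compound 2 both carry a six-membered aromatic ring on the chain attached to the amine nitrogen in the ring and both give low numbers; compound 3, whose chain there is only a methyl, gives the high one. Compound 4 keeps such an aromatic ring but loses the acetamido group and its hydrogen-bond donor and acceptor, so a step from compound 1 to compound 4 of a 2.7-fold higher number from compound 1 to compound 4 (0.43 log units; beyond the scatter) towards weaker inhibition is expected, near the edge of the scatter. Compound 4 is estimated at 150 nM, with a range from 40 nM to 600 nM.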

Compound 4, half-maximal inhibitory concentration: 85 nM
Compound 4: middle estimate off by 1.8-fold (0.25 log units), on the high side, and the stated range covers the measured number.
By their numbers in this assay, from the lowest: compounds 1, 4 and 2 (each within the scatter of the next); then compound 3.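

In this assay, phenethyl in place of 4-acetamidophenyl on a saturated chain carbon bound to an amine nitrogen in a ring gives a 1.5-fold higher number from compound 1 to compound 4 (0.18 log units; within the scatter), so the two compounds cannot be told apart on this read-out. Both keep a six-membered aromatic ring of carbon only, and the hydrogen-bond donor and hydrogen-bond acceptor counted for the group that leaves can go from this position without a step beyond the scatter. No other measurement is at hand that accounts for this result.

Compound 3 differs from compound 1 in more than one place, so the compounds shown do not isolate what the aromatic ring alone contributes at this position. From the compounds shown here alone, it also remains open how an amine or a carboxylic acid carried on the phenethyl of compound 4, or a longer chain in its place, would read in this assay on this position.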